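Methyl on an aromatic nitrogen of compound 1

The source may report more compounds than this note shows. Statements on the series, on what has been measured and on what is new or still open speak of the compounds shown alone.

Measured in a functional assay on SK-MEL-28 cells (Homo sapiens) for inhibition, read by MTT assay, with a stated time of 48 h; on this read-out lower numbers stand for stronger inhibition and higher numbers for weaker inhibition:
- compound 1 `COc1ccc(C/N=C2\NC(=O)/C(=C3\CCNC(=O)c4[nH]ccc43)S2)cc1`: 12100 nM
- compound 2 `O=C1N/C(=N\Cc2ccccc2Cl)S/C1=C1/CCNC(=O)c2[nH]ccc21`: > 100000 nM (a limit of the assay, not a number)
- compound 3 `O=C1N/C(=N\Cc2ccc(F)cc2)S/C1=C1/CCNC(=O)c2[nH]ccc21`: 11200 nM

Compound 1 and compound 3 stand level, with a 1.1-fold lower number from compound 1 to compound 3 (0.03 log units; within the scatter). Compound 2 has no exact number, only a limit.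

The next compound, compound 4 `COc1ccc(C/N=C2\NC(=O)/C(=C3\CCNC(=O)c4c3ccn4C)S2)cc1`, keeps everything in compound 1 except one site: methyl in place of hydrogen on an aromatic nitrogen. In words, methyl replaces hydrogen on an aromatic nitrogen. Going by the values given here, no measured step touches this nitrogen, as all of them swap the substituted phenyl group instead. Among the compounds with values here, they show only that a single change here can do little, as in a 1.1-fold lower number from compound 1 to compound 3 (0.03 log units; within the scatter), or much, as in an at least 8.2-fold higher number from compound 1 to compound 2 (0.91 log units; beyond the scatter). This leaves the direction open, so no step beyond the scatter is expected in this assay, with a slight lean toward a higher number and a wide range. The expected step is a 1.2-fold higher number from compound 1 to compound 4 (0.06 log units; within the scatter). For compound 4 the estimate is 14000 nM, with an expected range of 5000 nM to 50000 nM.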

Compound 4, half-maximal inhibitory concentration: > 100000 nM
Compound 4 gave a limit, no number; the forecaster's own chance of this, stated with the estimate: 15%; middle value at least 7.1-fold (0.85 log units) away from the limit.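

In this assay, the aromatic nitrogen of compound 1 proves sensitive to a very small change: methyl in place of hydrogen, adding only 1 heavy atom, gives an at least 8.2-fold higher number from compound 1 to compound 4 (0.91 log units; beyond the scatter). Going by these compounds alone, the earlier steps all swapped the substituted phenyl group, so this is the first sign that activity also depends on a site in the shared core. Compound 4 gives only a limit, not a number, so the step has a minimum size but no exact one, and the limit is one that recurs among these compounds: the limit of > 100000 nM in this assay, at which 2 of the 4 values shown sit.

One compound cannot tell whether the loss follows from removing the hydrogen or from adding the carbon group. Going by these compounds, how an ethyl group, a longer chain or an acetyl group on this nitrogen would read remains open, as does whether methyl here would act the same way alongside the 4-fluorophenyl group of compound 3.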